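Nitrooxy chain variants of the shared core and a hydroxy analogue

The source may hold more compounds than are shown below. What is called first, only, known or untested is meant among the compounds shown, and "the series" means these compounds.

Values in an assay on J774 cells for inhibition of prostaglandin G/H synthase 1 (Mus musculus), read by immunoassay, with stated times of 15 min and 30 min (a higher number here means a weaker inhibitor, a lower number a stronger inhibitor), each one a limit of the assay rather than a number:
compound 1, `Cc1c(CCOCCO[N+](=O)[O-])cc(-c2ccc(S(C)(=O)=O)cc2)n1-c1ccccc1`: > 10000 nM
compound 2, `Cc1c(CCOCCCO[N+](=O)[O-])cc(-c2ccc(S(C)(=O)=O)cc2)n1-c1ccccc1`: > 10000 nM
compound 3, `Cc1c(CCOCCCO[N+](=O)[O-])cc(-c2ccc(S(C)(=O)=O)cc2)n1-c1ccc(F)cc1`: > 10000 nM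

Compound 2 stands at the limit of this assay, and so do its two neighbours, as the limit of > 10000 nM in this assay, at which 3 of the 3 values shown sit, records. For the measured compounds named here, no order among the three can be read, and no compound can be called stronger or weaker than another. The step that the two limits leave unreadable from compound 1 to compound 2 is unreadable, since both ends are limits. The same holds for a step that the two limits leave unreadable from compound 2 to compound 3.

Compound 4, `Cc1c(CCOCCCO)cc(-c2ccc(S(C)(=O)=O)cc2)n1-c1ccccc1`, is not yet measured. It differs from compound 2 in one place: hydrogen in place of nitro on an oxygen on a saturated carbon. Going by the values given here, neither measured step touches this part of the structure, and neither has a readable size, so nothing among the measured values points to a change in one direction or the other. The shared core with the nitrooxy chain has given only limits in this assay, and compound 4 keeps that core with a hydroxy end on the chain. Compound 4 is therefore expected to sit at the limit as well, which would make the expected step that the limit leaves unreadable from compound 2 to compound 4 unreadable in turn. The estimate for compound 4 in this assay is 15000 nM, with a range from 4000 nM to 60000 nM.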

Compound 4, half-maximal inhibitory concentration: > 10000 nM
Compound 4: only a limit was reported; the forecaster's own chance of this, stated with the estimate: 80%; the middle value is on the limit's open side.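

In this assay, the steps from compound 1 and compound 2 to compound 4 cannot be read, as all of these values are limits of the assay: the limit of > 10000 nM in this assay, at which 4 of the 4 values shown sit.

The compounds shown leave open how strongly any of them acts in this assay, and whether the change from nitrooxy to hydroxy makes any difference there.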